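Removing the Benzyl Group from Compound 3

The source may hold more compounds than are shown below. What is called first, only, known or untested is meant among the compounds shown, and "the series" means these compounds.

In a functional assay on MIA PaCa-2 cells (Homo sapiens) for inhibition, read by MTT assay, with a stated time of 48 h, tested at 10 uM (a higher number here means more inhibition of growth at the concentration tested, a lower number less inhibition of growth), compound 3 `Cc1cc(=O)c2c(O)c(CN3CCC(Cc4ccccc4)CC3)c(O)c([C@H]3CCN(C)C[C@H]3O)c2o1` gives 18%. Compound 1 `Cc1cc(=O)c2c(O)cc(OCc3ccc(Br)cc3)c([C@H]3CCN(C)C[C@H]3O)c2o1` gives 13%, within the scatter of compound 3, while compound 2 `Cc1cc(=O)c2c(O)cc(OCc3ccco3)c([C@H]3CCN(C)C[C@H]3O)c2o1` gives 7%, a gap from compound 3 that lies beyond the scatter. Compound 4 `Cc1cc(=O)c2c(O)c(CN3CCCCC3)c(O)c([C@H]3CCN(C)C[C@H]3O)c2o1` differs from compound 3 by hydrogen in place of benzyl on a saturated ring carbon. Among the measured compounds shown here, the only measured step between single-place analogues, a number 6 percentage points lower from compound 1 to compound 2 (within the scatter), replaces 4-bromophenyl with furan-2-yl elsewhere in the structure and stays within the scatter. For the measured compounds named here, no measured step removes benzyl, so no change beyond the scatter is expected in this assay. The expected step is a number 4 percentage points lower from compound 3 to compound 4 (within the scatter). Compound 4 is estimated at 14%, with an expected range of 3% to 26%.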

Compound 4, percent growth inhibition at one concentration: 14%
Estimate against measurement, compound 4: no gap at the digits printed, and the stated range covers the measured number.
By their numbers in this assay, from the lowest: compounds 2, 1, 4 and 3 (each within the scatter of the next, the first and the last beyond it).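

Among the compounds shown here, removing benzyl from the saturated ring carbon, and with it one six-membered aromatic ring of carbon only, gives a number 4 percentage points lower from compound 3 to compound 4 (within the scatter) in this assay and is the first measured change at this position. The growth inhibition seen with compound 3 therefore does not depend, beyond the scatter, on benzyl at this ring carbon. Nothing measured here offers an explanation for this result.

From the compounds shown here alone, whether an amine, a carboxylic acid or a longer chain such as phenethyl on that ring carbon would move the number beyond the scatter remains open. So does the effect of replacing the ring nitrogen's six-membered ring with a morpholine.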